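Working notes: from compound 2 to compound 3

The source may report more compounds than this note shows. Statements on the series, on what has been measured and on what is new or still open speak of the compounds shown alone.

Measured so far in an ADME assay on HEK-293T cells (Homo sapiens) for inhibition, read by CCK-8 assay, with a stated time of 48 h, tested at 20 uM; on this read-out higher numbers stand for more inhibition of growth at the one concentration tested and lower numbers for less inhibition of growth:
- compound 1 `Cc1ccc(S(=O)(=O)Oc2ccccc2/C=C(\C#N)C(=O)Nc2nnc(C)s2)cc1` gives 35%
- compound 2 `Cc1nnc(NC(=O)/C(C#N)=C/c2cccc(OS(C)(=O)=O)c2)s1` gives 20%

Compound 2 stands lowest of the two numbers (20%), and the gap up to compound 1 lies beyond the usual scatter. The next compound is compound 3 `Cc1ccc(S(=O)(=O)Oc2cccc(/C=C(\C#N)C(=O)Nc3nnc(C)s3)c2)cc1`, which has 4-methylphenyl in place of methyl on a sulfonyl sulfur. Compound 1 also carries a (4-methylphenyl)sulfonyl group and shows the higher number (35%). Going by the values given here, no measured pair isolates this change, so the expectation rests on thin evidence. A modest rise near the edge of the scatter is expected, with the estimated step being a number 10 percentage points higher from compound 2 to compound 3 (within the scatter) in this read-out. For compound 3 the estimated value is 30% (expected range 15% to 45%).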

Compound 3, percent growth inhibition at one concentration: 27%
Compound 3: middle estimate off by 3 percentage points, on the high side; measured number inside the range.
By their numbers in this assay, from the lowest: compounds 2, 3 and 1 (each within the scatter of the next, the first and the last beyond it).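

In this assay, going by these compounds alone, the exchange of methyl for 4-methylphenyl on a sulfonyl sulfur gives a number 7 percentage points higher from compound 2 to compound 3 (within the scatter) and so provides the first direct reading of this change. At this position, on a sulfonyl sulfur whose other neighbour is an oxygen on an aromatic ring, the larger group with its six-membered aromatic ring is tolerated, but its effect cannot be told apart from the usual scatter. Nothing measured here speaks to a cause for this step.

On these data alone, whether an ethyl group, a longer alkyl chain or an aminophenyl group on the same sulfur would separate from methyl in this assay remains open. Also open, as far as these compounds go, is whether the same exchange would read alike on the core of compound 1.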